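The source may hold more compounds than are shown below. What is called first, only, known or untested is meant among the compounds shown, and "the series" means these compounds.

The three measured compounds share one core, carried by compound 1 `O=C(CCSc1nnc(-c2ccncc2)s1)Nc1ccc(Cl)cc1`, which in an ADME assay on HepG2 cells (Homo sapiens) for cytotoxicity, with a stated time of 3 days (on this read-out lower numbers stand for higher toxicity in this test and higher numbers for lower toxicity in this test), gives 7260 nM. Compound 3 `O=C(CCSc1nnc(-c2ccncc2)s1)NCc1ccccc1` gives 14000 nM in this assay. The step of a 1.9-fold higher number from compound 1 to compound 3 (0.29 log units; within the scatter) stays within the scatter. Compound 2 `CC(CSc1nnc(-c2ccncc2)s1)C(=O)Nc1ccc(Cl)cc1` stands apart from both. In this assay compound 2 reaches only the limit of > 50000 nM, so that no number, merely a bound, is known for it. Among the compounds with values here, the step of an at least 6.8-fold higher number from compound 1 to compound 2 (0.83 log units; beyond the scatter) is the one step beyond the scatter, and its size is set by the limit of > 50000 nM in this assay, at which 1 of the 3 values shown sits. Compound 4 `CC(CSc1nnc(-c2ccncc2)s1)C(=O)Nc1ccccc1` differs from compound 2 by hydrogen in place of chloro on an aromatic carbon. Within the data shown here, no measured step removes this chloro on its own. The nearest measured change, the exchange at the amide nitrogen, a 1.9-fold higher number from compound 1 to compound 3 (0.29 log units; within the scatter), stayed within the scatter, while the methyl that accompanied the move to a limit, an at least 6.8-fold higher number from compound 1 to compound 2 (0.83 log units; beyond the scatter), is kept in compound 4. The expected step in this assay is therefore a number no higher from compound 2 to compound 4 (the limit leaves the size open), none beyond the scatter, so that compound 4 would most likely again be reported as a limit. On that basis compound 4 is estimated at 50000 nM, with a range from 20000 nM to 150000 nM.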

Compound 4, half-maximal cytotoxic concentration: > 50000 nM
Compound 4: a limit, no number (the forecaster's own chance of this, stated with the estimate: 60%); the middle value sits exactly at the limit.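

Compound 4 gives > 50000 nM, which is a limit and not a number. Within the data shown here, no step from compound 2 to compound 4 can be read, since both compounds stand at a limit: the limit of > 50000 nM in this assay, at which 2 of the 4 values shown sit. The compounds shown leave open whether hydrogen in place of chloro on the aromatic carbon changes the read-out at all, and in which direction.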